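The source may report more compounds than this note shows. Statements on the series, on what has been measured and on what is new or still open speak of the compounds shown alone.

Measured so far in a functional assay for agonist activity at G protein-coupled receptor 88 (Homo sapiens), read by HTRF and cAMP accumulation; on this read-out lower numbers stand for an effect already at smaller amounts and higher numbers for an effect only at larger amounts of compound:
compound 1 `CN[C@@H](CC(C)C)CN(C(=O)[C@@H]1C[C@H]1c1ccccc1)c1ccc(-c2ccccc2)cc1` — 2 nM
compound 2 `CO[C@H](C)[C@H](N)CN(C(=O)[C@@H]1C[C@H]1c1ccccc1)c1ccc(-c2ccccc2)cc1` — 0.68 nM
compound 3 `CC[C@H](C)[C@H](N)CN(C(=O)[C@@H]1C[C@H]1c1cccc(Cl)c1)c1ccc(-c2ccccc2)cc1` — 2200 nM

Compound 3 stands highest of the three numbers; compound 1 is nearest and compound 2 furthest, both gaps beyond the scatter. Compound 4 `CC[C@H](C)[C@H](N)CN(C(=O)[C@@H]1C[C@H]1c1ccc(F)cc1)c1ccc(-c2ccccc2)cc1` differs from compound 3 by 4-fluorophenyl in place of 3-chlorophenyl on a saturated ring carbon. Going by the values given here, no measured step touches this place: the only single-change step, a 2.9-fold lower number from compound 1 to compound 2 (0.47 log units; beyond the scatter), concerns the chain on the amide-type nitrogen, and compounds 1 and 2 differ from compound 3 in more than one place, so their values give no reading on the group borne by the three-membered ring alone. No direction can be drawn; the step of a 1.5-fold lower number from compound 3 to compound 4 (0.17 log units; within the scatter) is expected to stay near the scatter, with wide uncertainty. Compound 4 is estimated at 1500 nM (range 200 nM to 10000 nM) in this assay.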

Compound 4, half-maximal effective concentration: 600 nM
The estimate for compound 4 lay 2.5-fold (0.40 log units) above the measured number, within the range that was stated.
By their numbers in this assay, from the lowest: compound 2; then compound 1; then compound 4; then compound 3.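

In this assay, going by these compounds alone, a 3.7-fold lower number from compound 3 to compound 4 (0.56 log units; beyond the scatter) gives the first reading at the group on the three-membered ring: the number at this saturated ring carbon responds to the aryl substituent, though only modestly. The change swaps the halogen and its ring position together, so the step belongs to the pair of changes and to neither alone. Nothing measured accounts for the step.

Open, going by these compounds, is how 4-chlorophenyl or 3-fluorophenyl would read on the same scaffold, which would separate the halogen from its position. Also open, on these data alone, is whether a pyridyl ring would be tolerated here.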